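From 2,3-dichlorophenyl to 2,4-dihydroxyphenyl on a shared core

This account rests on a few compounds, and the source may have more. Where it says the series, first, only, none or still open, it means among the compounds named here.

Of the compounds shown here, two with the same core have been tested so far, compound 1 `O=C(N/N=C/c1cccc(Br)c1)Nc1ccc(Oc2ccnc3[nH]ccc23)c(F)c1` and compound 2 `O=C(N/N=C/c1cccc(Cl)c1Cl)Nc1ccc(Oc2ccnc3[nH]ccc23)c(F)c1`. In a functional assay on MCF7 cells (Homo sapiens) for antiproliferative activity, read by MTT assay, with a stated time of 72 h (on this read-out lower numbers stand for stronger inhibition and higher numbers for weaker inhibition), compound 1 gives 49 nM. In this assay compound 2 is reported as "not active" (no number reported). Within the data shown here, compound 2 therefore has no number of its own, and no step can be measured from it.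

Compound 3 `O=C(N/N=C/c1ccc(O)cc1O)Nc1ccc(Oc2ccnc3[nH]ccc23)c(F)c1` carries 2,4-dihydroxyphenyl in place of 2,3-dichlorophenyl on a carbon with a double bond to nitrogen. Counted, the change runs (2,4-dihydroxyphenyl in place of 2,3-dichlorophenyl on a carbon with a double bond to nitrogen).

In this assay a measurable value is expected to take the place of the missing number, which would be a step towards stronger inhibition, though its size cannot be stated without a number for compound 2. This expectation leans on compound 1 at 49 nM, which shows that the shared core can give a measurable value. Compound 2 at "not active" (no number reported) is a reminder that a second result without a number remains possible. For compound 3 the estimated value is 400 nM, with an expected range from 40 nM to 4000 nM.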

Compound 3, half-maximal inhibitory concentration: 48000 nM
Estimate against measurement, compound 3: 120-fold (2.08 log units) below; the measured number lies above the stated range.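

In this assay, the group on a carbon with a double bond to nitrogen proves able to shift the result by a wide margin: 2,4-dihydroxyphenyl in place of 3-bromophenyl gives a 980-fold higher number from compound 1 to compound 3 (2.99 log units; beyond the scatter). The shared core alone therefore does not secure the strong value seen for compound 1, while compound 3 shows that a change at this place can leave a value that is much weaker but still measurable. The step between compound 2 and compound 3 cannot be read, and no measurement given here accounts for the large step from compound 1 to compound 3.

Because compound 3 differs from compound 1 in both the kind of substituent and how many the phenyl ring carries, these compounds do not show whether the loss follows from one hydroxyl group, from the pair, or from the absence of bromine. Going by these compounds, it also remains open whether a phenyl ring carrying a single methoxy group or an amine at this place would read closer to compound 1 or to compound 3.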